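The source may report more compounds than this note shows. Statements on the series, on what has been measured and on what is new or still open speak of the compounds shown alone.

Working notes on the series. Compound 1 `COc1cc(OC)c(C(=O)/C=C/c2ccccc2OC)c(OC)c1` sets the reference point: in an ADME assay on cells (Fibroblast, Homo sapiens) for cytotoxicity, with a stated time of 48 h (a lower number here means a stronger inhibitor, a higher number a weaker inhibitor), compound 1 gives 8200 nM. Compound 2 `COc1cc(OC)c(C(=O)/C=C/c2ccccc2SC)c(OC)c1` carries methylsulfanyl in place of methoxy on an aromatic carbon. In this assay compound 2 gives > 20000 nM, which is a limit of the assay and not a number (the limit of > 20000 nM in this assay, at which 1 of the 2 values shown sits). The step of an at least 2.4-fold higher number from compound 1 to compound 2 (0.38 log units; beyond the scatter) is thus known only as a bound, and compound 2 stands at the weak end of the two values shown.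

Compound 3 `COc1cccc(/C=C/C(=O)c2c(OC)cc(OC)cc2OC)c1` differs from compound 2 thus: 3-methoxyphenyl in place of 2-(methylsulfanyl)phenyl on a double-bonded chain carbon bound to a double-bonded chain carbon. Among the measured compounds shown here, a methoxy-bearing ring returns, but 3-methoxyphenyl is not the arrangement seen in compound 1, and no measured step covers that difference. For the measured compounds named here, the one measured step, an at least 2.4-fold higher number from compound 1 to compound 2 (0.38 log units; beyond the scatter), went in the weakening direction; its reversal points back toward the number of compound 1, with the remaining change unresolved. Compound 3 is expected at about 9000 nM, in the range 3000 nM to 30000 nM. The step of an at least 2.2-fold lower number from compound 2 to compound 3 (0.34 log units; beyond the scatter) is an estimate only.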

Compound 3, half-maximal inhibitory concentration: > 20000 nM
Compound 3: only a limit was reported (the forecaster's own chance of this, stated with the estimate: 30%); at least 2.2-fold (0.34 log units) between middle value and limit.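

In this assay, a methoxy group on the ring does not by itself keep a measurable value: 3-methoxyphenyl in place of 2-methoxyphenyl on a double-bonded chain carbon bound to a double-bonded chain carbon gives an at least 2.4-fold higher number from compound 1 to compound 3 (0.38 log units; beyond the scatter). Among the three compounds, only compound 1, with 2-methoxyphenyl, gives a reading short of the limit, so both changes made to its ring move the number the same way. Compound 2 and compound 3 both stand at a limit of the assay, and the step between them cannot be read: the limit of > 20000 nM in this assay, at which 2 of the 3 values shown sit.

As far as these compounds go, how far compound 2 and compound 3 lie beyond that limit stays open, so sulfur and the shifted methoxy cannot be ranked. Also open, from the compounds shown here alone, is whether a ring such as 2-aminophenyl or 2-hydroxyphenyl at this place would give a number near that of compound 1.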